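Methyl on the benzyl ring: cytotoxicity step from compound 3 to compound 4

The source may report more compounds than this note shows. Statements on the series, on what has been measured and on what is new or still open speak of the compounds shown alone.

Three compounds of the series have been run in an ADME assay on MT2 cells (Homo sapiens) for cytotoxicity, read by XTT assay, with a stated time of 4 days (a lower number here means that less compound is tolerated, a higher number that more compound is tolerated), and for all three only a limit is reported. Compound 1 `Cc1ccc2[nH]c(=O)c(CN(Cc3ccco3)C(=O)c3ccc(Cl)c(N4CCCCC4)c3)cc2c1` reaches the limit > 20400 nM in this assay, with no number inside the range. Compound 2 `Cc1cccc2cc(CN(Cc3ccccc3)C(=O)c3cccc(Cl)c3)c(=O)[nH]c12` reaches the limit > 60000 nM in this assay. Compound 3 `Cc1ccc2[nH]c(=O)c(CN(Cc3ccccc3)C(=O)c3ccco3)cc2c1` reaches the limit > 67100 nM in this assay, the limit at which one of the three values sits (the limit of > 67100 nM in this assay, at which 1 of the 3 values shown sits). Within the data shown here, no measured pair differs in a single place, so no step between measured compounds can be read; all that the three values show is that none of the compounds gave a number within the range of this assay.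

Compound 4 `Cc1ccc(CN(Cc2cc3cc(C)ccc3[nH]c2=O)C(=O)c2ccco2)cc1` is the next member to be measured. It differs from compound 3 in one place: methyl in place of hydrogen on an aromatic carbon. The change adds one carbon on an aromatic carbon of a six-membered aromatic ring of carbon only, para to a large group, and nothing else.

Given that compound 3 stands only at the limit (the limit of > 67100 nM in this assay, at which 1 of the 3 values shown sits), no step beyond the usual scatter is expected from compound 3 to compound 4 in this assay, that is an at least 1.1-fold lower number from compound 3 to compound 4 (0.04 log units; that floor lies within the scatter). Compound 4 is therefore estimated at 60000 nM, with a range from 20000 nM to 150000 nM, and most likely it too will be reported only as a limit.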

Compound 4, half-maximal cytotoxic concentration: > 19800 nM
Compound 4: a limit, no number (the forecaster's own chance of this, stated with the estimate: 80%); the middle value lies beyond the limit too.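

Among these compounds, compound 3 and compound 4 are both reported only as limits in this assay, and no step between them can be read. The compounds shown leave open where the half-maximal cytotoxic concentration of any of them lies, and whether the change from benzyl to 4-methylbenzyl shifts it at all.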